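Sulfonyl group swap at the cytotoxicity limit

A few compounds are considered here, and "the series" means these few. Any claim that something is new, unique, unknown or untested is made for them only; others in the source may bear on it.

Values so far in an ADME assay on HCT-116 cells (Homo sapiens) for cytotoxicity, read by CellTiter-Glo, with a stated time of 72 h (a lower number here means a stronger inhibitor, a higher number a weaker inhibitor), for the series:
- compound 1 `CC1CCN(C2CCN(S(=O)(=O)c3cccnc3)CC2)CC1` gives > 10000 nM as a limit
- compound 2 `CC1CCN(C2CCN(S(=O)(=O)c3ccc(Br)c(Cl)c3)CC2)CC1` gives > 5000 nM as a limit

Compound 2 stands only at its limit, with no number to place it. Compound 3 `CC1CCN(C2CCN(S(=O)(=O)c3cn(C)cn3)CC2)CC1` differs from compound 2 by the change 1-methyl-1H-imidazol-4-yl in place of 4-bromo-3-chlorophenyl on a sulfonyl sulfur in which 1-methyl-1H-imidazol-4-yl takes the place of 4-bromo-3-chlorophenyl on a sulfonyl sulfur. Among the measured compounds shown here, the one measured step bearing on this is a step that the two limits leave unreadable from compound 1 to compound 2 with 4-bromo-3-chlorophenyl in place of pyridin-3-yl on a sulfonyl sulfur. Both ends of that step are limits, so it offers no size to carry over. In this assay no step beyond the scatter is expected, and no direction is favoured. The expected step is a step that the limit leaves unreadable from compound 2 to compound 3 and another limit is the likeliest report. Compound 3 is estimated at 10000 nM with an expected range from 5000 nM to 30000 nM in this assay for now.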

Compound 3, half-maximal inhibitory concentration: > 10000 nM
Compound 3: no number, only a limit; the forecaster's own chance of this, stated with the estimate: 85%; the middle value sits exactly at the limit.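

Among the compounds shown here, compound 1, compound 2 and compound 3 all stand only at limits in this assay, and no step among them can be read. The compounds shown leave open where each true value lies and whether the three differ at all.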